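The source may report more compounds than this note shows. Statements on the series, on what has been measured and on what is new or still open speak of the compounds shown alone.

Of the compounds shown here, three in this set have been measured in an assay for inhibition of HSP60/HSP10 (Homo sapiens), with a stated time of 60 min; on this read-out higher numbers stand for weaker inhibition and lower numbers for stronger inhibition. Compound 1 `O=S(=O)(Nc1ccc2oc(-c3ccc(NS(=O)(=O)c4cccc5nonc45)cc3)nc2c1)c1ccc(Cl)s1` gives 11000 nM in this assay, the lowest of the three numbers and so the strongest inhibition seen here. Compound 3 `O=[N+]([O-])c1ccc(S(=O)(=O)Nc2ccc(-c3nc4cc(NS(=O)(=O)c5ccc([N+](=O)[O-])cc5)ccc4o3)cc2)cc1` gives 51000 nM in this assay, and compound 2 `O=S(=O)(Nc1ccc(-c2nc3cc(NS(=O)(=O)c4cccc(C(F)(F)F)c4)ccc3o2)cc1)c1cccc(C(F)(F)F)c1` gives 58000 nM. Both of those gaps to compound 1 lie beyond the usual scatter, so compound 1 is clearly ahead of the other two, although every number in the set describes rather weak inhibition.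

Compound 4 `O=[N+]([O-])c1cc(S(=O)(=O)Nc2ccc(-c3nc4cc(NS(=O)(=O)c5ccc(Cl)s5)ccc4o3)cc2)ccc1Cl` keeps one half of compound 1 unchanged and alters the other sulfonyl group: a group of 10 heavy atoms (6 carbon, 1 nitrogen, 2 oxygen, 1 chlorine; one six-membered aromatic ring of carbon only) in place of a group of 9 heavy atoms (6 carbon, 2 nitrogen, 1 oxygen; one five-membered aromatic ring with 3 hetero atoms, one six-membered aromatic ring of carbon only), on a sulfonyl sulfur. Within the data shown here, no pair of measured compounds shows this particular exchange, so there is no measured step to lean on; the change swaps one aromatic sulfonyl partner for another of similar size, and none of the three measured compounds points in a clear direction for it.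

The expectation is therefore a step from compound 1 to compound 4 of a 1.6-fold higher number from compound 1 to compound 4 (0.21 log units; within the scatter) in this assay, which is within or only just beyond the scatter, leaning slightly toward weaker inhibition. Compound 4 is estimated to give 18000 nM in this assay, with a likely range from 6000 nM to 60000 nM.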

Compound 4, half-maximal inhibitory concentration: 2100 nM
Compound 4: the middle estimate sits 8.6-fold (0.93 log units) above what was measured; measured number below the stated range.
By their numbers in this assay, from the lowest: compound 4; then compound 1; then compounds 3 and 2 (each within the scatter of the next).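

Replacing the group on this sulfonyl sulfur, with the rest of compound 1 left untouched, gives a 5.2-fold lower number from compound 1 to compound 4 (0.72 log units; beyond the scatter) in this assay and is beyond the usual scatter. This shows that the choice of group at this one position can clearly change the inhibition, and that 4-chloro-3-nitrophenyl does better here than the two-ring group it replaces. The three earlier compounds differ from one another in more than one place, so they could not credit any change to a single group, and nothing measured here explains why this exchange helps.

Because 4-chloro-3-nitrophenyl carries both a chlorine and a nitro group, the compounds shown leave open whether one of them accounts for the gain or both are needed, which a phenyl ring bearing only the chlorine or only the nitro group could test. Going by these compounds, it also remains open whether an amine or a carboxylic acid could take the place of the nitro group, and whether 4-chloro-3-nitrophenyl would give a similar step with a different group on the other sulfonyl sulfur.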